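The compounds below may be only part of what the source reports. "The series", "measured", "known", "first", "only" and "open" are said of these compounds alone.

Measured compounds in an in vitro functional assay on cells for agonist activity at Bombesin receptor subtype-3 (Homo sapiens), read by luminescence and calcium flux; on this read-out higher numbers stand for an effect only at larger amounts of compound and lower numbers for an effect already at smaller amounts:
Compound 1, `N#Cc1cccc(Cc2cnc(CCc3ccc(-c4ccccc4C(=O)O)cc3)[nH]2)c1`, gives 812 nM.
Compound 2, `CC(C)CCc1cnc(CCc2ccc(-c3ccccc3C(=O)O)cc2)[nH]1`, gives 119 nM.
Compound 3, `O=C(O)c1ccccc1-c1ccc(CCc2ncc(Cc3cccc(F)c3F)[nH]2)cc1`, gives 87 nM.

Compound 3 has the lowest number of the three in this assay. Its step from compound 1 is clear, a 9.3-fold lower number from compound 1 to compound 3 (0.97 log units; beyond the scatter), while its step from compound 2 is a 1.4-fold lower number from compound 2 to compound 3 (0.14 log units; within the scatter), so compound 2 and compound 3 cannot be separated on these numbers.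

Compound 4, `O=C(O)c1ccccc1-c1ccc(CCc2ncc(Cc3cccc(Cl)c3)[nH]2)cc1`, has not been measured. It differs from compound 3 in one place: 3-chlorophenyl in place of 2,3-difluorophenyl on a saturated chain carbon bound to an aromatic carbon.

Two of the measured steps bear on this change, since both alter the same saturated chain carbon bound to an aromatic carbon. Replacing 3-cyanophenyl with isobutyl gave a 6.8-fold lower number from compound 1 to compound 2 (0.83 log units; beyond the scatter), and replacing it with 2,3-difluorophenyl gave a 9.3-fold lower number from compound 1 to compound 3 (0.97 log units; beyond the scatter); the two replacements ended up within the scatter of each other, a 1.4-fold lower number from compound 2 to compound 3 (0.14 log units; within the scatter). Nothing measured here distinguishes a 3-chlorophenyl from a 2,3-difluorophenyl in this position, so compound 4 is expected to stay near compound 3, with a step of a 1.4-fold higher number from compound 3 to compound 4 (0.14 log units; within the scatter), not clearly beyond the scatter. Compound 4 is therefore estimated at 120 nM in this assay, within a range from 40 nM to 400 nM.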

Compound 4, half-maximal effective concentration: 825 nM
Compound 4: the middle estimate sits 6.9-fold (0.84 log units) below what was measured, and the stated range ends below it.
By their numbers in this assay, from the lowest: compounds 3 and 2 (each within the scatter of the next); then compounds 1 and 4 (each within the scatter of the next).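

In this assay, going by these compounds alone, this position proves sensitive to which substituted phenyl it carries, which the earlier compounds did not reveal: 3-chlorophenyl in place of 2,3-difluorophenyl gives a 9.5-fold higher number from compound 3 to compound 4 (0.98 log units; beyond the scatter) and 3-chlorophenyl in place of isobutyl gives a 6.9-fold higher number from compound 2 to compound 4 (0.84 log units; beyond the scatter), so a phenyl ring alone does not keep the number low. Chloro in place of cyano on the aromatic carbon gives a 1.0-fold higher number from compound 1 to compound 4 (0.01 log units; within the scatter) and so makes no difference that can be read, which leaves compound 1 and compound 4 together above the pair of compound 2 and compound 3. Nothing available here accounts for the gap between the 2,3-difluorophenyl and 3-chlorophenyl groups.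

Compound 3 and compound 4 differ in both the kind and the number of halogens, so a phenyl carrying a single fluorine or one carrying two chlorines would be needed to separate those two changes. Also open, on these data alone, is how an unsubstituted phenyl, a methoxy group on the phenyl or a longer alkyl chain would read at this carbon.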